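Piperidinyl in Place of Isopropylamino on the Amide Side Chain

This account rests on a few compounds, and the source may have more. Where it says the series, first, only, none or still open, it means among the compounds named here.

Among the three compounds measured in a functional assay on the whole organism for inhibition of sodium-dependent dopamine transporter (Mus musculus) (a lower number here means that less compound is needed, a higher number that more compound is needed for the effect), compound 3 `CC(C)NCC(=O)Nc1cccc2c1CN(C)CC2c1ccccc1` gives about 30 mg/kg, the highest of the three numbers. Compound 1 `CN1Cc2c(N)cccc2C(c2ccc(F)cc2)C1` gives 7.5 mg/kg, and compound 2 `CCOC(=O)Nc1cccc2c1CN(C)CC2c1ccc(F)cc1` gives 4.6 mg/kg. Within the data shown here, the only step between compounds that differ in one place, a 1.6-fold lower number from compound 1 to compound 2 (0.21 log units; within the scatter), lies within the scatter; it concerns an ethoxycarbonyl group on an aromatic nitrogen and not the side chain. Compound 4 `CN1Cc2c(NC(=O)CN3CCCCC3)cccc2C(c2ccccc2)C1` differs from compound 3 by piperidin-1-yl in place of isopropylamino on a saturated chain carbon bound to a carbonyl carbon. Among the measured compounds shown here, no measured step covers a change of this kind: the two compounds carrying a chain on the amide are compound 3 alone among the measured ones, and the data give no step between an open chain amine and a ring amine. One therefore expects for compound 4 in this assay a number near that of compound 3, with no step beyond the scatter that the data would support. Compound 4 is expected to give 25 mg/kg, within a range from 8 mg/kg to 80 mg/kg. The estimated step from compound 3 to compound 4 is thus a 1.2-fold lower number from compound 3 to compound 4 (0.08 log units; within the scatter).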

Compound 4, dose for half-maximal effect: about 60 mg/kg
Estimate against measurement, compound 4: 2.4-fold (0.38 log units) below, within the range that was stated.
By their numbers in this assay, from the lowest: compounds 2 and 1 (each within the scatter of the next); then compounds 3 and 4 (each within the scatter of the next).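

In this assay the chain on the amide now has its first measured step: a 2.0-fold higher number from compound 3 to compound 4 (0.30 log units; within the scatter). On a saturated chain carbon bound to a carbonyl carbon, piperidin-1-yl with its six-membered non-aromatic ring can thus stand in place of isopropylamino, and the open chain amine and the ring amine are not separated beyond the scatter in this read-out. Nothing available here bears on why the two numbers stand as they do.

From the compounds shown here alone, whether another ring amine, such as pyrrolidin-1-yl or morpholin-4-yl, or a longer chain carrying the same amine would remain as close to compound 3 stays open. The compounds shown also offer no single change that links either amine side chain to the ethoxycarbonyl group of compound 2.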